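The source may report more compounds than this note shows. Statements on the series, on what has been measured and on what is new or still open speak of the compounds shown alone.

Compound 1 `CCC1C(=O)N(C)c2cnc(-n3ccc4cc(C(=O)NCC(C)C)ccc43)nc2N1c1ccn(C)n1` is the weaker growth inhibitor of the two measured compounds: in a functional assay on A549 cells (Homo sapiens) for antiproliferative activity, read by CCK-8 assay, with a stated time of 72 h (a lower number here means a stronger inhibitor of growth, a higher number a weaker inhibitor of growth), compound 1 gives 19200 nM, the higher of the two numbers. The other measured compound, compound 2 `CC[C@@H]1C(=O)N(C)c2cnc(-n3ccc4cc(C(N)=O)ccc43)nc2N1C1CCCC1`, gives 4350 nM in this assay, a lower number beyond the scatter, but it differs from compound 1 in several places, so no single step can be read between them. Compound 3 `CCC1C(=O)N(C)c2cnc(-n3ccc4cc(C(=O)NC5CCCC5)ccc43)nc2N1c1ccn(C)n1` changes compound 1 in one place only: cyclopentyl in place of isobutyl on an amide-type nitrogen. Neither measured compound shows what this swap does, so in this assay only a small step, if any, is expected: a 1.3-fold lower number from compound 1 to compound 3 (0.11 log units; within the scatter). Compound 3 is therefore estimated at 15000 nM, with a range from 6000 nM to 40000 nM.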

Compound 3, concentration for 50% growth inhibition: 39500 nM
Compound 3: the middle estimate sits 2.6-fold (0.42 log units) below what was measured, within the range that was stated.
By their numbers in this assay, from the lowest: compound 2; then compound 1; then compound 3.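

In this assay, cyclopentyl in place of isobutyl on the amide-type nitrogen gives a 2.1-fold higher number from compound 1 to compound 3 (0.31 log units; beyond the scatter) as a modest but real weakening of growth inhibition. The group on this nitrogen therefore affects the result, and here the carbon ring does worse than the open branched chain. No evidence available here gives a reason for this step. Still open, going by these compounds, is how a methyl group, a longer chain or a chain ending in an amine would behave at this nitrogen on the same core.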